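Inverting Both Stereocentres of Compound 1

The source may hold more compounds than are shown below. What is called first, only, known or untested is meant among the compounds shown, and "the series" means these compounds.

Compound 1 `CN1C[C@H]2C=C(c3cccnc3)C[C@H](C2)C1` and compound 2 `C1=C(c2ccc(-c3ccccc3)nc2)CC2CNCC1C2` were both tested in an in vitro functional assay on SH-SY5Y cells for agonist activity at Neuronal acetylcholine receptor; alpha3/beta4 (Homo sapiens), read by FLIPR and calcium flux; on this read-out lower numbers stand for an effect already at smaller amounts and higher numbers for an effect only at larger amounts of compound. Compound 1 gives 7530 nM, and compound 2 gives 10900 nM; the two numbers lie within the usual scatter of each other, so neither stands apart. Compound 3 `CN1C[C@@H]2C=C(c3cccnc3)C[C@@H](C2)C1` differs from compound 1 in this way: the two compounds have the same atoms and bonds and differ only in configuration as drawn: 2 of 2 stereo elements differ (all stereocentres are inverted: mirror images); a stereocentre at a saturated ring carbon is drawn R in compound 1 and S in compound 3; a stereocentre at a saturated ring carbon is drawn S in compound 1 and R in compound 3. Within the data shown here, no measured pair shows what such a mirror-image change does in this assay, so the step from compound 1 to compound 3 could run either way, and a loss seems about as plausible as no change beyond the scatter. Compound 3 is expected at 12000 nM, between 3000 nM and 50000 nM. The expected step is a 1.6-fold higher number from compound 1 to compound 3 (0.20 log units; within the scatter).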

Compound 3, half-maximal effective concentration: > 10000 nM
Compound 3: only a limit was reported (the forecaster's own chance of this, stated with the estimate: 15%); the middle value does not contradict the limit.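

In this assay compound 3 gives > 10000 nM, which is a limit of the assay and not a number. Inverting both stereocentres now has a first reading in this series, an at least 1.3-fold higher number from compound 1 to compound 3 (0.12 log units; that floor lies within the scatter), so a real loss and no change beyond the scatter both remain possible. The reading is only a floor, and what sets it is this: the limit of > 10000 nM in this assay, at which 1 of the 3 values shown sits.

On these data alone, how large the mirror-image step really is stays open. As far as these compounds go, it also stays open whether a nitrile or a hydroxyl group on the core of compound 1 would move the value in this assay.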